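Shortening a side chain amide in an oral tail flick series

The source may hold more compounds than are shown below. What is called first, only, known or untested is meant among the compounds shown, and "the series" means these compounds.

Compound 1 `NC(=O)CC[C@H](NC(=O)CN(c1ncnc2c1ncn2C1CCCCO1)C1CC1)C(=O)OCc1ccccc1`: 10.7%
Compound 2 `O=C(CN(c1nc(Cl)nc2[nH]cnc12)C1CC1)N[C@@H](CO)C(=O)O`: 18.8%

In a functional assay on the whole organism (Tail, strain ICR) with Mus musculus as the target, in the tail flick test, with a stated time of 150 min, at a dose of 25 umol/kg by the oral route (a higher number here means a stronger effect of the compound at the dose given, a lower number a weaker effect), compound 1 gives the smaller of the two numbers, and compound 2 lies within the usual scatter of it, so the two are not separated. Compound 3 `NC(=O)C[C@H](NC(=O)CN(c1ncnc2c1ncn2C1CCCCO1)C1CC1)C(=O)OCc1ccccc1` differs from compound 1 by carbamoyl in place of carbamoylmethyl on a saturated chain carbon, two bonds along the chain from an amide-type nitrogen and a carbonyl carbon. Going by the values given here, no step between measured compounds is available here, so the size of such a change cannot be read from the data. The step of a number 1.3 percentage points higher from compound 1 to compound 3 (within the scatter) is expected to be small, in either direction, and not beyond the scatter. Compound 3 is therefore estimated to give 12%, in a range from 0% to 30%.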

Compound 3, a percentage reported as activity, at one dose (the size of the read-out at that dose, not a potency): 21.7%
Estimate against measurement, compound 3: 9.7 percentage points below; low and high end bracket the measured number.
By their numbers in this assay, from the lowest: compounds 1, 2 and 3 (each within the scatter of the next, the first and the last beyond it).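

Moving from 2-carbamoylethyl to carbamoylmethyl on a saturated chain carbon, two bonds along the chain from an amide-type nitrogen and a carbonyl carbon, gives in this assay a number 11 percentage points higher from compound 1 to compound 3 (beyond the scatter) and provides the first step that can be read at this position. The response at this dose is therefore not indifferent to this change, although the step is modest and rests on one pair. Nothing available explains the step.

From the compounds shown here alone, what a longer chain such as 3-carbamoylpropyl would give at this position remains open. So does the effect of a carboxylic acid or an amine in place of the carbamoyl.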